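Compound 3 and its carboxy amide successor, compound 4

This account rests on a few compounds, and the source may have more. Where it says the series, first, only, none or still open, it means among the compounds named here.

Compound 1 `CCN(CC)CCNC(=O)c1cc(C(CC)(CC)c2ccc(C#CC(O)(CC)CC)c(C)c2)cn1CC`: 5350 nM
Compound 2 `CCn1cc(C(CC)(CC)c2ccc(C#CC(O)(CC)CC)c(C)c2)cc1C(=O)NCCCN(C)C`: 15100 nM
Compound 3 `CCn1cc(C(CC)(CC)c2ccc(C#CC(O)(CC)CC)c(C)c2)cc1C(=O)OCCO`: 11400 nM

All three compounds were tested in a functional assay on PC-3 cells (Homo sapiens) for antiproliferative activity, read by MTT assay, with a stated time of 72 h; a higher number here means a weaker inhibitor, a lower number a stronger inhibitor. Compound 3, at 11400 nM, holds the second highest of the three numbers. Compound 4 `CCn1cc(C(CC)(CC)c2ccc(C#CC(O)(CC)CC)c(C)c2)cc1C(=O)N[C@H](C(=O)O)C(C)C` has not yet been measured. It carries (1-carboxy-2-methylpropyl)amino in place of 2-hydroxyethoxy on a carbonyl carbon.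

Two measured steps involve exchanges on that same carbonyl carbon. One is a 2.1-fold higher number from compound 1 to compound 3 (0.33 log units; beyond the scatter), which is modest. The other is a 1.3-fold lower number from compound 2 to compound 3 (0.12 log units; within the scatter). Neither step introduces a carboxy group, so they offer only a loose guide. In this assay, the swap is therefore expected to produce no change beyond the scatter, although a modest move in either direction remains possible. The estimate is a 1.2-fold higher number from compound 3 to compound 4 (0.09 log units; within the scatter). The expected value for compound 4 is 14000 nM, within an estimated range of 5000 nM to 40000 nM.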

Compound 4, half-maximal inhibitory concentration: 3750 nM
Compound 4: middle estimate off by 3.7-fold (0.57 log units), on the high side; measured number below the stated range.
By their numbers in this assay, from the lowest: compounds 4 and 1 (each within the scatter of the next); then compounds 3 and 2 (each within the scatter of the next).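

Placed on this carbonyl carbon, (1-carboxy-2-methylpropyl)amino gives the first clear gain over the 2-hydroxyethoxy group in this assay (a 3.0-fold lower number from compound 3 to compound 4 (0.48 log units; beyond the scatter)), and on the amide-type nitrogen it also outperforms 3-(dimethylamino)propyl (a 4.0-fold lower number from compound 2 to compound 4 (0.60 log units; beyond the scatter)). The earlier compounds carried an amine on the amide chain or a hydroxyl on the ester chain, yet compound 4 has neither and still matches the 2-(diethylamino)ethyl chain of compound 1 (a 1.4-fold lower number from compound 1 to compound 4 (0.15 log units; within the scatter)), so an amine on this chain is not needed to reach that level among these compounds. Nothing shown here explains these differences.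

The compounds shown do not separate the carboxylic acid from the branched isopropyl part of the new group. As far as these compounds go, a methyl ester in place of the acid, or a glycine amide without the isopropyl branch, would address that question, and the opposite configuration at the stereocentre also remains open.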